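A few compounds are considered here, and "the series" means these few. Any claim that something is new, unique, unknown or untested is made for them only; others in the source may bear on it.

Of the compounds shown here, three sharing one core have been tested in an assay on membranes from CHO cells for displacement of a labelled ligand from adenosine receptor A1 (Homo sapiens), read by scintillation counting, with a stated time of 60 min, tested at 1 uM; a higher number here means more inhibition at the concentration tested (going by the name of the read-out), a lower number less inhibition. Compound 1 `CCCC(=O)C1=C(C)NC(=O)NC1c1ccsc1` gives 6%. Among the measured compounds shown here, compound 2 `CC1=C(C(=O)SC(C)C)C(c2ccsc2)NC(=O)N1` gives 24%, and the only measured step between close neighbours, a number 18 percentage points higher from compound 1 to compound 2 (beyond the scatter), concerns the group on the carbonyl carbon. Compound 3 `CCC(CC)OC(=O)C1=C(C)NC(=O)NC1c1cccs1` gives 13%, the second highest of the three numbers; its nearest neighbour is compound 1, within the scatter, and its furthest is compound 2, beyond the scatter.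

Compound 4 `CCC(CC)OC(=O)C1=C(C)NC(=O)NC1c1ccsc1` has not yet been measured and differs from compound 3 in one place: thiophen-3-yl in place of thiophen-2-yl on a saturated ring carbon. For the measured compounds named here, no measured step swaps the thiophenyl attachment in this way; the step from compound 1 to compound 2 alters a different part of the molecule and so does not bear on it. Compound 1 and compound 2 both carry thiophen-3-yl, yet one lies within the scatter of compound 3 and the other beyond it, so the attachment alone does not separate the numbers. The expected step of no change at the digits printed from compound 3 to compound 4 (within the scatter) is therefore none beyond the scatter. Compound 4 is estimated at 13%, within a range from 0% to 30%.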

Compound 4, a percentage reported as inhibition, at one concentration (the size of the read-out at that concentration, not a potency): 22%
Estimate against measurement, compound 4: 9 percentage points below, and the stated range covers the measured number.
By their numbers in this assay, from the lowest: compounds 1, 3, 4 and 2 (each within the scatter of the next, the first and the last beyond it).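

The direct swap of thiophen-2-yl for thiophen-3-yl on the saturated ring carbon gives a number 9 percentage points higher from compound 3 to compound 4 (within the scatter) in this assay, so this pair does not tell the two attachments apart. With thiophen-3-yl held constant, (pentan-3-yl)oxy in place of isopropylsulfanyl on the carbonyl carbon gives a number 2 percentage points lower from compound 2 to compound 4 (within the scatter), while (pentan-3-yl)oxy in place of propyl gives a number 16 percentage points higher from compound 1 to compound 4 (beyond the scatter), so both groups now have a step beyond the scatter from propyl. No supporting measurement is available to explain these numbers.

As far as these compounds go, it remains open whether a phenyl or furan-2-yl group on that saturated ring carbon would give a step beyond the scatter. Also open, from the compounds shown here alone, is how an amine or a longer chain on the carbonyl carbon would compare with (pentan-3-yl)oxy and isopropylsulfanyl.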